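The source may report more compounds than this note shows. Statements on the series, on what has been measured and on what is new or still open speak of the compounds shown alone.

Of the compounds shown here, three with a shared core have been tested in a functional assay on KB cells (Homo sapiens) for inhibition, read by MTT assay, with a stated time of 24 h, tested at 0.1 ug/mL; on this read-out lower numbers stand for less inhibition of growth and higher numbers for more inhibition of growth at the one concentration tested. Compound 1 (`O=C(CCCCC1CCSS1)NO`) gives 7.92%, compound 2 (`O=C(CCCCC1CCSS1)Nc1ccccc1Cl`) gives 5.11%, and compound 3 (`O=C(CCCCC1CCSS1)Nc1ccc([N+](=O)[O-])c(C(F)(F)F)c1`) gives 4.5%. Compound 1 therefore stands level with the other two, as all three values lie within the usual scatter of one another.

Compound 4 (`O=C(CCCCC1CCSS1)Nc1ccccn1`) has not been measured yet. It differs from compound 1 by a single change, pyridin-2-yl in place of hydroxy on an amide-type nitrogen.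

For the measured compounds named here, no two tested compounds differ in only one place, so no measured step can serve as a direct guide. Even so, compound 2 with 5.11% and compound 3 with 4.5% also carry a ring on that nitrogen, and neither stands apart from compound 1 beyond the scatter. In this assay, no step beyond the scatter is expected, in either direction. The expected step is a number 1.9 percentage points lower from compound 1 to compound 4 (within the scatter). Compound 4 is estimated at 6%, with an expected range from 0% to 16%.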

Compound 4, percent growth inhibition at one concentration: "not active" (no number reported)
Compound 4: no number reported; the estimate stays without a comparison.
By their numbers in this assay, from the lowest: compounds 3, 2 and 1 (each within the scatter of the next).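

In this assay, for the compounds shown here, compound 4 is reported only as "not active", without a number, so no step from compound 1 to compound 4 can be read. The compounds shown leave open whether pyridin-2-yl in place of hydroxy changes growth inhibition at all, and nothing given here explains this result.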